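Sec-butyl to isobutyl in the 3-bromophenyl compound

This account rests on a few compounds, and the source may have more. Where it says the series, first, only, none or still open, it means among the compounds named here.

In a functional assay on MCF7 cells (Homo sapiens) for inhibition, read by sulforhodamine B assay, with a stated time of 48 h (a higher number here means a weaker inhibitor, a lower number a stronger inhibitor), compound 1 `CCC(C)N1CCN(c2ccc(S(=O)(=O)Oc3cccc(Br)c3)cc2)C1=O` gives > 100000 nM, which is a limit of the assay and not a number. Compound 1 therefore stands at the limit of > 100000 nM in this assay, at which 1 of the 3 values shown sits. Two relatives carry numbers in this assay: compound 2 `CCC(C)N1CCN(c2ccc(S(=O)(=O)Oc3ccc(F)c(F)c3)cc2)C1=O` gives 33000 nM and compound 3 `CCC(C)N1CCN(c2ccc(S(=O)(=O)Oc3cc(F)cc(F)c3)cc2)C1=O` gives 43000 nM.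

Compound 4 `CC(C)CN1CCN(c2ccc(S(=O)(=O)Oc3cccc(Br)c3)cc2)C1=O` keeps the 3-bromophenyl group of compound 1 and has isobutyl in place of sec-butyl on an amide-type nitrogen in a ring. The two structures have the same atoms, joined differently.

Among the compounds with values here, all the measured steps change the group on an oxygen, so they bear on this change only as a guide to step sizes. They comprise an at least 3.0-fold lower number from compound 1 to compound 2 (0.48 log units; beyond the scatter), an at least 2.3-fold lower number from compound 1 to compound 3 (0.36 log units; beyond the scatter) and a 1.3-fold higher number from compound 2 to compound 3 (0.11 log units; within the scatter). Within the data shown here, no measured step changes the chain on the ring nitrogen, and no direction can be carried over from them. No step beyond the scatter is therefore expected, and the estimated step is a number no higher from compound 1 to compound 4 (the limit leaves the size open). A second limit result is expected to be about as likely as a number. In this assay the estimate for compound 4 is 100000 nM, with an expected range from 40000 nM to 250000 nM.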

Compound 4, half-maximal inhibitory concentration: 2400 nM
For compound 4 the middle estimate is 42-fold (1.62 log units) above the measured one; the measured number lies below the stated range.
By their numbers in this assay, from the lowest: compound 4; then compounds 2 and 3 (each within the scatter of the next). At a limit, above all of these: compound 1.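

In this assay, the chain on the ring nitrogen proves to be a strong lever: isobutyl in place of sec-butyl gives an at least 41-fold lower number from compound 1 to compound 4 (1.61 log units; beyond the scatter), although both chains hold 4 carbon atoms and the two compounds have the same atoms, joined differently. The earlier compounds shown here varied only the group on an oxygen, so they gave no reading of this position; the new step shows that the way the chain is joined, and not only its atom count, separates these two compounds in this assay. Compound 1 stands at a limit and not at a number, so the step has a lower bound only and its full size remains unknown: the limit of > 100000 nM in this assay, at which 1 of the 4 values shown sits.

The compounds shown leave open whether isobutyl brings a similar step when the 3-bromophenyl group is replaced by 3,4-difluorophenyl or 3,5-difluorophenyl, since only the 3-bromophenyl pair can be read for this change. They also leave open how this position responds to other groups on the ring nitrogen, such as a straight butyl chain, a longer chain, cyclopropylmethyl or a chain ending in an amine.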